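This account rests on a few compounds, and the source may have more. Where it says the series, first, only, none or still open, it means among the compounds named here.

Compounds measured in a functional assay on HeLa cells (Homo sapiens) for antiproliferative activity, read by MTT assay, with a stated time of 48 h; on this read-out higher numbers stand for weaker inhibition and lower numbers for stronger inhibition:

compound 1, `Cn1c(N)c(-c2nc3ccccc3[nH]2)c2nc(C#N)c(C#N)nc21`, > 50000 nM
compound 2, `N#Cc1nc2c(-c3nc4ccccc4[nH]3)c(N)n(CCN3CCCC3)c2nc1C#N`, > 50000 nM
compound 3, `N#Cc1nc2c(-c3nc4ccccc4[nH]3)c(N)n(CCCO)c2nc1C#N`, > 50000 nM

Each of these three values is a limit of this assay and not a number. Compound 3 therefore stands at the limit, at the same level as the other two, and no order among the three can be read. The steps between the measured compounds, a step that the two limits leave unreadable from compound 1 to compound 2, a step that the two limits leave unreadable from compound 1 to compound 3 and a step that the two limits leave unreadable from compound 2 to compound 3, all remain unreadable because of the limit of > 50000 nM in this assay, at which 3 of the 3 values shown sit.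

Compound 4, `N#Cc1nc2c(-c3nc4ccccc4[nH]3)c(N)n(CCCNc3ccccc3)c2nc1C#N`, differs from compound 3 by anilino in place of hydroxy on a saturated chain carbon, three bonds along the chain from an aromatic nitrogen. The measured steps that bear on this change are the three substitutions on the chain bound to the aromatic nitrogen, and none of them gives a size or a direction, so nothing can be carried over to this assay beyond the fact that every variation of the chain so far has left the value at the limit. The expectation for compound 4 is accordingly another value at or near the limit. Compound 4 is estimated at 60000 nM, with a range from 10000 nM to 300000 nM. The step that the limit leaves unreadable from compound 3 to compound 4 this estimate implies is expected to be none beyond the scatter.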

Compound 4, half-maximal inhibitory concentration: 26300 nM
For compound 4 the middle estimate is 2.3-fold (0.36 log units) above the measured one; the measured number falls inside the stated range.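

In this assay, among these compounds, compound 4 is the first of the series to give a number and not a limit, so the 3-anilinopropyl chain yields a reading that the earlier chains did not. Against those limits the result is an at least 1.9-fold lower number from compound 3 to compound 4 (0.27 log units; that floor lies within the scatter), an at least 1.9-fold lower number from compound 2 to compound 4 (0.27 log units; that floor lies within the scatter) and an at least 1.9-fold lower number from compound 1 to compound 4 (0.27 log units; that floor lies within the scatter); a change beyond the scatter is therefore not shown, and the true size of each step stays unfixed. The steps among compound 1, compound 2 and compound 3 cannot be read, because of this: the limit of > 50000 nM in this assay, at which 3 of the 4 values shown sit.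

As far as these compounds go, whether the reading in compound 4 depends on the aromatic ring or on the chain nitrogen stays open. A benzylamino group, a substituted anilino group or a longer chain could test how far the value moves from this position.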